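The source may report more compounds than this note shows. Statements on the series, on what has been measured and on what is new or still open speak of the compounds shown alone.

Measured so far:
compound 1, `Cc1nccn1-c1cnc(NCc2c(F)ccc3c2CCO3)c2cn[nH]c(=O)c12`, gives 7000 nM
compound 2, `O=C(Nc1cnc(NCc2c(F)ccc3c2CCO3)n2cnnc12)c1ccccc1`, gives 2000 nM
compound 3, `Fc1ccc2c(c1CNc1ncc(Nc3ccccc3)c3nncn13)CCO2`, gives 3000 nM

In a physicochemical assay for solubility, read by LC-MS, in phosphate buffer, with a stated time of 24 h, at pH 7.4 (on this read-out lower numbers stand for lower solubility and higher numbers for higher solubility), compound 1 stands highest of the three numbers. Compound 3 sits lower at 3000 nM, and compound 2 lower still at 2000 nM, though compounds 2 and 3 lie within the scatter of each other. Within the data shown here, the only step between two measured compounds is a 1.5-fold higher number from compound 2 to compound 3 (0.18 log units; within the scatter), and it concerns a different core and a different kind of exchange, so it does not bear on the change in question. Compound 4, `Cc1ncccc1-c1cnc(NCc2c(F)ccc3c2CCO3)c2cn[nH]c(=O)c12`, differs from compound 1 by 2-methylpyridin-3-yl in place of 2-methyl-1H-imidazol-1-yl on an aromatic carbon. Among the measured compounds shown here, no measured pair shows what this exchange does to solubility, so there is nothing to set a direction. The expectation is a step of no size beyond the scatter, held with wide uncertainty. Compound 4 is therefore estimated at 5000 nM, with a range from 1500 nM to 15000 nM. This estimate means an expected step of a 1.4-fold lower number from compound 1 to compound 4 (0.15 log units; within the scatter).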

Compound 4, solubility: < 2000 nM
Compound 4: only a limit was reported (the forecaster's own chance of this, stated with the estimate: 5%); middle value at least 2.5-fold (0.39 log units) from the limit.
By their numbers in this assay, from the lowest: compounds 2 and 3 (each within the scatter of the next); then compound 1.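

In this assay, compound 4 returns a limit of the assay rather than a number, < 2000 nM. Putting 2-methylpyridin-3-yl in place of 2-methyl-1H-imidazol-1-yl gives an at least 3.5-fold lower number from compound 1 to compound 4 (0.54 log units; beyond the scatter), the first step read at this place on the core of compound 1. The number read here therefore depends on which aromatic ring sits at this position, something compounds 2 and 3, on a different core, could not show.

With only these two groups at this place, this single pair cannot separate ring size, the count of ring nitrogens and the extra heavy atom from one another. The compounds shown also leave open how a group without an aromatic ring, such as a morpholine or a simple amine, would read here in this assay.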